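Swapping Methoxy for Methylsulfanyl on a Shared Core

The compounds below may be only part of what the source reports. "The series", "measured", "known", "first", "only" and "open" are said of these compounds alone.

Of the compounds shown here, three built on one shared core have been tested in a functional assay on NCI/ADR-RES cells (Homo sapiens) for inhibition, read by sulforhodamine B assay, with a stated time of 48 h; a higher number here means a weaker inhibitor of growth, a lower number a stronger inhibitor of growth. Compound 1 `CCOC(=O)C1=C(C)NC(=S)NC1c1ccc(O)c(O)c1` gives 24.3 ug/mL. Compound 2 `CCOC(=O)C1=C(C)NC(=O)NC1c1ccc(O)c(O)c1` gives 2.1 ug/mL in this assay. Compound 3 `CCOC(=O)C1=C(C)NC(=S)NC1c1ccc(OC)cc1` gives 3.2 ug/mL in this assay, the second highest of the three numbers: it sits within the usual scatter of the number for compound 2, while compound 1 lies beyond the scatter above it. Compound 4 `CCOC(=O)C1=C(C)NC(=S)NC1c1ccc(SC)cc1` has not yet been measured. It differs from compound 3 in one place: methylsulfanyl in place of methoxy on an aromatic carbon. For the measured compounds named here, no measured pair shows what this swap does. The step of a 1.1-fold lower number from compound 3 to compound 4 (0.03 log units; within the scatter) in this assay is expected to be no larger than the scatter, in no firm direction. Compound 4 is therefore expected to give 3 ug/mL, estimated between 1.2 ug/mL and 7.5 ug/mL.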

Compound 4, concentration for 50% growth inhibition: 35.7 ug/mL
For compound 4 the middle estimate is 12-fold (1.08 log units) below the measured one; the measured number lies above the stated range.
By their numbers in this assay, from the lowest: compounds 2 and 3 (each within the scatter of the next); then compounds 1 and 4 (each within the scatter of the next).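

On an aromatic carbon para to a large group, this swap is far from neutral in this assay: methylsulfanyl in place of methoxy gives an 11-fold higher number from compound 3 to compound 4 (1.05 log units; beyond the scatter) and so a weaker inhibitor of growth. The change matters even though the counts of heavy atoms, hydrogen-bond donors and hydrogen-bond acceptors stay the same. Nothing available explains the step. On these data alone, whether ethoxy, a longer chain or an amine at this place would keep the number of compound 3 remains open. So does whether the swap would act alike on another core.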